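Compound 4 in the HepG2 cytotoxicity assay

A few compounds are considered here, and "the series" means these few. Any claim that something is new, unique, unknown or untested is made for them only; others in the source may bear on it.

Compound 1 `Cc1ccc(-c2nc3ccccc3s2)cc1NC(=O)c1cc([N+](=O)[O-])c(N2CCC(C(=O)O)CC2)cc1Cl`: > 25000 nM
Compound 2 `COc1ccc(-c2nc3ccccc3s2)cc1NC(=O)c1cc([N+](=O)[O-])ccc1Cl`: > 25000 nM
Compound 3 `COc1ccc(-c2nc3ccccc3s2)cc1NC(=O)c1cc([N+](=O)[O-])c(N2CCC(C(=O)O)CC2)cc1Cl`: > 25000 nM

All three compounds were tested in an ADME assay on HepG2 cells (Homo sapiens) for cytotoxicity, with a stated time of 72 h (on this read-out lower numbers stand for an effect already at smaller amounts and higher numbers for an effect only at larger amounts of compound), and each value is a limit of the assay, not a number. The picture is uniform: the limit of > 25000 nM in this assay, at which 3 of the 3 values shown sit. Compound 3 stands at such a limit, > 25000 nM.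

In compound 4 `COc1ccc(-c2nc3ccccc3s2)cc1NC(=O)c1cc([N+](=O)[O-])c(N2CCN(C)CC2)cc1Cl`, 4-methylpiperazin-1-yl takes the place of the 4-carboxypiperidin-1-yl of compound 3: 4-methylpiperazin-1-yl in place of 4-carboxypiperidin-1-yl on an aromatic carbon. Among the compounds with values here, two measured steps bear on this change: a step that the two limits leave unreadable from compound 1 to compound 3 and a step that the two limits leave unreadable from compound 2 to compound 3. The second adds the group that now leaves, but neither step has a readable size.

The step expected in this assay is therefore small, an at least 1.2-fold lower number from compound 3 to compound 4 (0.09 log units; that floor lies within the scatter), with no firm direction. For compound 4 the estimated value is 20000 nM, with an expected range from 7000 nM to 40000 nM.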

Compound 4, half-maximal effective concentration: > 25000 nM
Compound 4 was reported as a limit; the forecaster's own chance of this, stated with the estimate: 60%; middle value at least 1.2-fold (0.09 log units) from the limit.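

In this assay, within the data shown here, compound 4 gives > 25000 nM, which is a limit and not a number, so no step from compound 2 or compound 3 to compound 4 can be read. The compounds shown leave open whether any of these changes alters the read-out at all, as all of them share one result: the limit of > 25000 nM in this assay, at which 4 of the 4 values shown sit.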